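Bromination of a benzofuranyl thiazolyl urea abolishes activity

A few compounds are considered here, and "the series" means these few. Any claim that something is new, unique, unknown or untested is made for them only; others in the source may bear on it.

Compound 2 `COc1cccc(NC(=O)Nc2nc(-c3cc4ccccc4o3)cs2)c1` gives 200 nM in a physicochemical assay, with a stated time of 6 min; a higher number here means a weaker inhibitor, a lower number a stronger inhibitor. Compound 1 `O=C(Nc1ccc(F)cc1)Nc1nc(-c2cc3ccccc3o2)cs1` differs from compound 2 by 4-fluorophenyl in place of 3-methoxyphenyl on an amide-type nitrogen and in this assay compound 1 gives 1130 nM, a step of a 5.7-fold higher number from compound 2 to compound 1 (0.75 log units; beyond the scatter). Compound 3 `COc1cccc(NC(=O)Nc2nc(-c3cc4cc(Br)ccc4o3)cs2)c1` differs from compound 2 by bromo in place of hydrogen on an aromatic carbon. In this assay compound 3 reaches only the limit > 200000 nM, so the step of an at least 1000-fold higher number from compound 2 to compound 3 (3.00 log units; beyond the scatter) is itself a limit, resting on (the limit of > 200000 nM in this assay, at which 1 of the 3 values shown sits). Compound 4 `O=C(Nc1ccc(F)cc1)Nc1nc(-c2cc3cc(Br)ccc3o2)cs1` is not yet measured and differs from compound 3 by 4-fluorophenyl in place of 3-methoxyphenyl on an amide-type nitrogen, the same change as from compound 2 to compound 1. Because a 5.7-fold higher number from compound 2 to compound 1 (0.75 log units; beyond the scatter) made the number higher, compound 4 is expected to sit at or beyond the limit, a step that the limit leaves unreadable from compound 3 to compound 4. The estimate for compound 4 is 600000 nM, between 200000 nM and 3000000 nM.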

Compound 4, half-maximal inhibitory concentration: > 200000 nM
Compound 4 was reported as a limit (the forecaster's own chance of this, stated with the estimate: 90%); the middle value lies beyond the limit too.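

In this assay compound 4 gives only a limit, > 200000 nM. The change from 3-methoxyphenyl to 4-fluorophenyl therefore shows no readable size on the core of compound 3, and it cannot be said whether it acts there as it does on the core of compound 2, because both compounds on that core stand at a limit: the limit of > 200000 nM in this assay, at which 2 of the 4 values shown sit.

The bromo in place of hydrogen gives an at least 170-fold higher number from compound 1 to compound 4 (2.24 log units; beyond the scatter), so the large loss seen with 3-methoxyphenyl also appears with 4-fluorophenyl. The compounds shown leave open whether chloro, fluoro or methyl on that aromatic carbon would bring the same loss, or whether it is confined to bromo.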